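A fluoro-to-bromo swap on the benzyl group

A few compounds are considered here, and "the series" means these few. Any claim that something is new, unique, unknown or untested is made for them only; others in the source may bear on it.

Measured in a functional assay on U-251 cells (Homo sapiens) for antiproliferative activity, read by MTT assay, with a stated time of 24 h; on this read-out lower numbers stand for stronger inhibition and higher numbers for weaker inhibition:
- compound 1 `COc1cccc(C(=O)Oc2ccc3c(=O)c(-c4cc(OC)c(OC)cc4OC)coc3c2)c1`: > 10000 nM (a limit of the assay)
- compound 2 `COc1cc(OC)c(-c2coc3cc(OCc4cccc(F)c4)ccc3c2=O)cc1OC`: 3510 nM

For the measured compounds named here, compound 2 holds the only actual number in this assay so far, at 3510 nM. For compound 1, the entry of > 10000 nM is a limit of the assay and not a number.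

The next compound is compound 3 `COc1cc(OC)c(-c2coc3cc(OCc4cccc(Br)c4)ccc3c2=O)cc1OC`, which carries bromo in place of fluoro on an aromatic carbon, turning the 3-fluorobenzyl group into 3-bromobenzyl: bromo in place of fluoro on an aromatic carbon.

Going by the values given here, only one measured step bears on this change. The step of an at least 2.8-fold lower number from compound 1 to compound 2 (0.45 log units; beyond the scatter) replaced the whole group on the oxygen and introduced the 3-fluorobenzyl group, so it shows that this group matters. It does not compare one halogen with another, so it gives only weak guidance here. With a single heavy atom exchanged at that position, no step beyond the scatter is expected, and no direction can be favoured.

The estimated change is a 1.2-fold lower number from compound 2 to compound 3 (0.07 log units; within the scatter).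

Compound 3 is expected at about 3000 nM, with an estimated range of 1100 nM to 9000 nM.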

Compound 3, half-maximal inhibitory concentration: > 10000 nM
Compound 3: only a limit was reported (the forecaster's own chance of this, stated with the estimate: 12%); at least 3.3-fold (0.52 log units) between middle value and limit.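

Among the earlier compounds, the 3-fluorobenzyl group had been compared only with the (3-methoxyphenyl)carbonyl group, so nothing yet showed whether the halogen on it mattered. Exchanging fluoro for bromo gives an at least 2.8-fold higher number from compound 2 to compound 3 (0.45 log units; beyond the scatter), which shows that one heavy atom at this place on the aromatic ring is enough to lose the measurable number, although the ring count and the counts of hydrogen-bond donors and acceptors stay the same. Compound 2 therefore remains the only compound with an actual number in this assay, and the step between compound 1 and compound 3 cannot be read, as both entries are limits of the assay: the limit of > 10000 nM in this assay, at which 2 of the 3 values shown sit.

The compounds shown leave open how a chloro or a methyl group at this place would read in this assay, and whether a plain benzyl group without any halogen would keep a measurable number. They also leave open how far past its limit the true value of compound 3 lies.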